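Swapping one carboxy for a tetrazole in compound 2

The source may hold more compounds than are shown below. What is called first, only, known or untested is meant among the compounds shown, and "the series" means these compounds.

Values in a functional assay on the whole organism with Rattus norvegicus as the target, at a dose of 25 mg/kg by the intravenous route (on this read-out higher numbers stand for an effect only at larger amounts of compound and lower numbers for an effect already at smaller amounts), are as follows
Compound 1 `N#Cc1ccc(C(=O)Nc2ccc(-c3nn[nH]n3)cc2)cc1` gives 2.4 mg/kg
Compound 2 `O=C(O)c1ccc(NC(=O)c2ccc(C(=O)O)cc2)cc1` gives 25.4 mg/kg

Compound 2 stands highest of these two numbers, and its gap to compound 1 lies beyond the scatter. Compound 3 `O=C(O)c1ccc(NC(=O)c2ccc(-c3nn[nH]n3)cc2)cc1` comes from compound 2 by one change 2H-tetrazol-5-yl in place of carboxy on an aromatic carbon in which 2H-tetrazol-5-yl takes the place of carboxy on an aromatic carbon. Within the data shown here, no measured pair shows this exchange alone, so any forecast rests on little. Compound 1 (at 2.4 mg/kg) also carries 2H-tetrazol-5-yl and has the lower number, so a shift towards lower numbers in this assay is expected. The expected size is an estimated step of a 3.2-fold lower number from compound 2 to compound 3 (0.50 log units; beyond the scatter) that goes beyond the scatter. The estimate for compound 3 is 8 mg/kg with an expected range from 2 mg/kg to 30 mg/kg in this read-out.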

Compound 3, dose for 50% inhibition: 2.3 mg/kg
The estimate for compound 3 lay 3.5-fold (0.54 log units) above the measured number; the measured number falls inside the stated range.
By their numbers in this assay, from the lowest: compounds 3 and 1 (each within the scatter of the next); then compound 2.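

In this assay, among these compounds, the exchange of carboxy for 2H-tetrazol-5-yl on this aromatic carbon brings an 11-fold lower number from compound 2 to compound 3 (1.04 log units; beyond the scatter) and is the first change in this set that can be read on its own. Compound 1 and compound 2 differ in more than one place, so their gap could not be tied to any single group, whereas this pair ties a large step to one carboxy. Compound 3 still carries its other carboxy, which shows that a carboxy left elsewhere in the molecule does not prevent an effect at smaller amounts.

The compounds shown do not tell whether that remaining carboxy can be exchanged in the same way, or how a sulfonic acid, a methyl ester or a primary amide would fare at the exchanged place. Among the compounds shown here, nothing available explains why this exchange moves the number so far.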